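Series notes: trifluoromethyl on the pendant phenyl

This account rests on a few compounds, and the source may have more. Where it says the series, first, only, none or still open, it means among the compounds named here.

Compound 2 `CC#CC(CC(=O)O)c1ccc(OCc2ccn3cc(-c4ccccc4)nc3c2)cc1` is the reference point. For the measured compounds named here, in an assay on isolated protein for agonist activity at Free fatty acid receptor 1 (Homo sapiens) (on this read-out higher numbers stand for an effect only at larger amounts of compound and lower numbers for an effect already at smaller amounts), compound 2 gives 1260 nM, the highest of the three numbers measured so far. Compound 1 `CC#CC(CC(=O)O)c1ccc(OCc2ccc3nc(-c4ccc(C(F)(F)F)cc4)cn3c2)cc1`, which carries 4-(trifluoromethyl)phenyl on a different core, gives 558 nM in this assay. Compound 3 `CC#CC(CC(=O)O)c1ccc(OCc2ccn3cc(-c4ccc(C)cc4C)nc3c2)cc1` stands on the same core as compound 2 but carries 2,4-dimethylphenyl. In this assay compound 3 gives 503 nM.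

The move to compound 4 `CC#CC(CC(=O)O)c1ccc(OCc2ccn3cc(-c4ccc(C(F)(F)F)cc4)nc3c2)cc1` is trifluoromethyl in place of hydrogen on an aromatic carbon; read one bond further out, it is phenyl to 4-(trifluoromethyl)phenyl, the group standing on a six-membered aromatic ring of carbon only, para to a large group.

Two observations bear on it. Within the same core, a 2.5-fold lower number from compound 2 to compound 3 (0.40 log units; beyond the scatter), so substituting this phenyl has lowered the number once already. Between the cores no single-point difference exists, but compound 2 gives 1260 nM and compound 1 gives 558 nM, so compound 1, the one bearing the trifluoromethyl, stands lower. A modest downward step in this assay is therefore expected, of roughly the size seen with compound 3. The expected step is a 2.5-fold lower number from compound 2 to compound 4 (0.40 log units; beyond the scatter). Compound 4 is estimated at 500 nM, with a range from 250 nM to 1000 nM.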

Compound 4, half-maximal effective concentration: 674 nM
For compound 4 the middle estimate is 1.3-fold (0.13 log units) below the measured one; measured number inside the range.
By their numbers in this assay, from the lowest: compounds 3, 1, 4 and 2 (each within the scatter of the next, the first and the last beyond it).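

In this assay, placing trifluoromethyl on this aromatic carbon, para to a large group, gives a 1.9-fold lower number from compound 2 to compound 4 (0.27 log units; within the scatter), so this change cannot be told apart from leaving hydrogen there, whereas the 2,4-dimethylphenyl of compound 3 did give a step beyond the scatter from compound 2. Exchanging one substituted phenyl for the other gives a 1.3-fold higher number from compound 3 to compound 4 (0.13 log units; within the scatter), so on the shared core 4-(trifluoromethyl)phenyl and 2,4-dimethylphenyl cannot be separated in this read-out, and the step beyond the scatter seen with compound 3 does not carry over as a clear step for every substituent on this phenyl. Nothing at hand bears on why these numbers stand where they do.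

Going by these compounds, whether another group on this same carbon, such as methoxy, a nitrile or an amine, would move the number clearly beyond the scatter from compound 2 remains open, as does whether a single methyl would do so. Also open, on these data alone, is how much of the standing of a substituted phenyl depends on the shared core rather than on the core of compound 1, which carries the same 4-(trifluoromethyl)phenyl.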